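The source may hold more compounds than are shown below. What is called first, only, known or untested is meant among the compounds shown, and "the series" means these compounds.

Working notes on the series. In a functional assay on NCI-H460 cells (Homo sapiens) for cytotoxicity, read by resazurin assay, with a stated time of 72 h (a higher number here means a weaker inhibitor, a lower number a stronger inhibitor), compound 1 `COc1cc(/C=C/C(=O)OCCCCCCO[N+](=O)[O-])ccc1O` reads > 50000 nM, and this value is a limit of the assay, not a number. Within the data shown here, compound 2 `COc1cc(/C=C/C(=O)OCCCO[N+](=O)[O-])ccc1O` gives 29000 nM, the only true number so far, so it has no measured neighbour to be ranked against.

Compound 3 `COc1cc(/C=C/C(=O)OC/C=C/CO[N+](=O)[O-])ccc1O` differs from compound 2 by a group of 7 heavy atoms (3 carbon, 1 nitrogen, 3 oxygen; no ring) in place of a group of 6 heavy atoms (2 carbon, 1 nitrogen, 3 oxygen; no ring), on a saturated chain carbon bound to an oxygen next to a carbonyl group. The entering group has 2 double bonds outside aromatic rings, and the leaving 2-(nitrooxy)ethyl has 1.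

Among the measured compounds shown here, the single measured step is an at least 1.7-fold lower number from compound 1 to compound 2 (0.23 log units; that floor lies within the scatter). With one end resting on a limit (the limit of > 50000 nM in this assay, at which 1 of the 2 values shown sits), it gives a floor and not a size. It also involves no added double bond outside aromatic rings, so it bears only loosely on this change. No step beyond the scatter is therefore expected in this assay, and no direction can be argued. The expected outcome is a 1.0-fold lower number from compound 2 to compound 3 (0.02 log units; within the scatter).

Compound 3 is estimated at 28000 nM, with an expected range from 12000 nM to 60000 nM.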

Compound 3, half-maximal inhibitory concentration: 4980 nM
Beside the measured number, compound 3's estimate is 5.6-fold (0.75 log units) above it; the measured number lies below the stated range.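

In this assay, among these compounds, the change on a saturated chain carbon bound to an oxygen next to a carbonyl group gives a 5.8-fold lower number from compound 2 to compound 3 (0.77 log units; beyond the scatter), the first step with a measured size at both ends. Among the compounds shown here, compound 1 reads > 50000 nM, which is a limit and not a number, so the only earlier step gave a floor and no size. The entering group differs from 2-(nitrooxy)ethyl both in its carbon count, 3 carbon against 2 carbon, and in having 2 double bonds outside aromatic rings against 1, and nothing measured here assigns a cause for the step to either difference.

As far as these compounds go, whether the extra carbon or the extra double bond carries the step remains open, and a saturated 3-(nitrooxy)propyl group at this same place would be the direct comparison for compound 3. Also open, from the compounds shown here alone, is how much of the step depends on the nitrooxy end itself, which a plain hydroxyl in its place on the chain of compound 3 would address, and whether the geometry of the double bond matters, which its cis form would address.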